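Cyclobutyl in place of cyclopropyl on the amide carbonyl

The compounds below may be only part of what the source reports. "The series", "measured", "known", "first", "only" and "open" are said of these compounds alone.

Compound 1, `CCC(=O)Nc1c(C(O)(C(F)(F)F)C(F)(F)F)ccc2ccccc12`, gives 96% in a functional assay (Sus scrofa) with sulfonylurea receptors; K-ATP channels (Homo sapiens) as the target; a lower number here means a smaller maximal response, a higher number a larger maximal response. Compound 2, `CCCC(=O)Nc1c(C(O)(C(F)(F)F)C(F)(F)F)ccc2ccccc12`, gives 92%. Compound 3, `O=C(Nc1c(C(O)(C(F)(F)F)C(F)(F)F)ccc2ccccc12)C1CC1`, gives 100%.

Compound 3 carries the highest of the three numbers, yet all three lie within the scatter of one another: a number 4 percentage points higher from compound 1 to compound 3 (within the scatter), a number 8 percentage points higher from compound 2 to compound 3 (within the scatter), and a number 4 percentage points lower from compound 1 to compound 2 (within the scatter).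

Compound 4 is `O=C(Nc1c(C(O)(C(F)(F)F)C(F)(F)F)ccc2ccccc12)C1CCC1`. Against compound 3 the difference is cyclobutyl in place of cyclopropyl on a carbonyl carbon.

Among the measured compounds shown here, the steps that bear on this are the two exchanges on the carbonyl carbon, from ethyl and from propyl to cyclopropyl, both within the scatter. A further growth of the group on the carbonyl carbon is therefore expected to give no step beyond the scatter in this assay, so for compound 4 the estimate is 97%, range 87% to 105%, meaning an expected a number 3 percentage points lower from compound 3 to compound 4 (within the scatter).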

Compound 4, largest response reached (reported as efficacy), in percent of the reference or control that the assay uses: 97%
Compound 4: the middle estimate sits on the measured number at the digits printed, and the stated range covers the measured number.
By their numbers in this assay, from the lowest: compounds 2, 1, 4 and 3 (each within the scatter of the next).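

In this assay, the tolerance at this position extends to a four-membered ring on the carbonyl carbon: cyclobutyl in place of cyclopropyl gives no step beyond the scatter (a number 3 percentage points lower from compound 3 to compound 4 (within the scatter)). The same holds against the open chains, for cyclobutyl in place of propyl (a number 5 percentage points higher from compound 2 to compound 4 (within the scatter)) and cyclobutyl in place of ethyl (a number 1 percentage points higher from compound 1 to compound 4 (within the scatter)). Nothing available explains why the response stays level across these groups.

Still open, on these data alone, is whether a phenyl ring, an amine or a carboxylic acid on the carbonyl carbon would give a step beyond the scatter. Also open, as far as these compounds go, is what a methyl group in place of the amide hydrogen would do.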